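Dropping the methyl from compound 2

This account rests on a few compounds, and the source may have more. Where it says the series, first, only, none or still open, it means among the compounds named here.

Compound 1 `Cc1ccc(-c2cs/c(=N/NC(=O)CSc3nnnn3-c3ccccc3)n2-c2ccccc2)cc1`: > 500 ug/mL, a limit of the assay
Compound 2 `Cc1ccc(-c2cs/c(=N/NC(=O)CSc3nnnn3C)n2-c2ccccc2)cc1`: 243 ug/mL

Going by the values given here, in an ADME assay on NIH3T3 cells (Mus musculus) for cytotoxicity, read by MTT assay, with a stated time of 24 h (on this read-out higher numbers stand for weaker inhibition and lower numbers for stronger inhibition), compound 2 gives 243 ug/mL, the only actual number so far. Compound 1 gives only a limit, > 500 ug/mL.

Compound 3 `Cn1nnnc1SCC(=O)N/N=c1/scc(-c2ccccc2)n1-c1ccccc1` has not yet been measured. It differs from compound 2 by hydrogen in place of methyl on an aromatic carbon, which turns 4-methylphenyl into phenyl.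

Among the compounds with values here, only one measured step is available. That step, an at least 2.0-fold lower number from compound 1 to compound 2 (0.31 log units; beyond the scatter), put methyl in place of phenyl on an aromatic nitrogen and not on this aromatic carbon, so it bears on the new change only loosely and sets no direction for it. On that basis, no step beyond the scatter is expected in this assay. The expected step is a 1.0-fold higher number from compound 2 to compound 3 (0.01 log units; within the scatter). The estimate for compound 3 is 250 ug/mL, with an expected range from 120 ug/mL to 500 ug/mL.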

Compound 3, half-maximal inhibitory concentration: 173 ug/mL
For compound 3 the middle estimate is 1.4-fold (0.16 log units) above the measured one; low and high end bracket the measured number.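

In this assay, going from 4-methylphenyl to phenyl gives a 1.4-fold lower number from compound 2 to compound 3 (0.15 log units; within the scatter). Going by these compounds alone, this is the first reading at this place, on an aromatic carbon of the six-membered aromatic ring of carbon only, para to a large group; the one earlier step concerned a group on an aromatic nitrogen, so it said nothing about this position. Here the methyl gives way to hydrogen with no step beyond the scatter, so compound 2 and compound 3 cannot be told apart on this read-out, and nothing in the data shown accounts for the size of this step.

With only methyl and hydrogen shown at this place, it remains open whether a larger or quite different group there, such as a methoxy group, a chlorine atom, an amine or a carboxylic acid, would shift the number beyond the scatter. As far as these compounds go, it is also open whether the same change from 4-methylphenyl to phenyl would read alike in a compound with phenyl rather than methyl on the aromatic nitrogen.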